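Three Limits and an Ester-Bearing Piperidine

The compounds below may be only part of what the source reports. "The series", "measured", "known", "first", "only" and "open" are said of these compounds alone.

Compound 1 `COc1cc2c(Nc3ccc(C#N)cc3)ncnc2cc1OCCCN(C)Cc1ccccc1` gives > 100000 nM in a functional assay on SH-SY5Y cells (Homo sapiens) for antiproliferative activity, read by MTT assay, with a stated time of 72 h (on this read-out higher numbers stand for weaker inhibition and lower numbers for stronger inhibition), a limit of the assay.
Compound 2 `COc1cc2c(Nc3ccc(C#N)cc3)ncnc2cc1OCCCN1CCC(O)CC1` gives > 100000 nM in this assay, again a limit.
Compound 3 `COc1cc2c(Nc3ccc(C#N)cc3)ncnc2cc1OCCCN1CCCCC1CCO` gives > 100000 nM in this assay, likewise a limit.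

Compound 3 therefore stands at the limit, as do both other compounds, and the steps a step that the two limits leave unreadable from compound 1 to compound 3 and a step that the two limits leave unreadable from compound 2 to compound 3 cannot be read in size. Compound 4 `CCOC(=O)C1CCN(CCCOc2cc3ncnc(Nc4ccc(C#N)cc4)c3cc2OC)CC1` carries the change (4-(ethoxycarbonyl)piperidin-1-yl in place of 2-(2-hydroxyethyl)piperidin-1-yl on a saturated chain carbon, three bonds along the chain from an oxygen on an aromatic ring). Among the compounds with values here, because every value shown sits at the limit of > 100000 nM in this assay, at which 3 of the 3 values shown sit, no measured step shows whether changing the group on this chain moves the read-out at all. The step that the limit leaves unreadable from compound 3 to compound 4 is therefore expected to be small or unreadable. Compound 4 is estimated at 150000 nM, within 60000 nM to 500000 nM.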

Compound 4, half-maximal inhibitory concentration: 47200 nM
Compound 4: middle estimate off by 3.2-fold (0.50 log units), on the high side; measured number below the stated range.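

Replacing 2-(2-hydroxyethyl)piperidin-1-yl with 4-(ethoxycarbonyl)piperidin-1-yl gives an at least 2.1-fold lower number from compound 3 to compound 4 (0.32 log units; beyond the scatter) in this assay, so the group on this chain can move the read-out. Ethoxycarbonyl in place of hydroxy on a saturated ring carbon gives an at least 2.1-fold lower number from compound 2 to compound 4 (0.32 log units; beyond the scatter), and 4-(ethoxycarbonyl)piperidin-1-yl in place of benzyl(methyl)amino gives an at least 2.1-fold lower number from compound 1 to compound 4 (0.32 log units; beyond the scatter). Each size is only a minimum, and the steps among the three earlier compounds remain unreadable, since all of them rest on one limit: the limit of > 100000 nM in this assay, at which 3 of the 4 values shown sit.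

The compounds shown leave open whether a carboxylic acid or a primary amide in place of ethoxycarbonyl would keep this lower number. They also leave open what a longer chain would do.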